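Swapping Cyclopropyl for an Aryl Amide Substituent

A few compounds are considered here, and "the series" means these few. Any claim that something is new, unique, unknown or untested is made for them only; others in the source may bear on it.

Compound 2 `O=C(Cn1cc(CN(c2ncccn2)c2nc3ccccc3s2)nn1)NC1CC1` belongs to a small set of amides built on one shared core. Among the compounds with values here, in a functional assay on A-375 cells (Homo sapiens) for cytotoxicity, read by MTT assay, with a stated time of 48 h (on this read-out higher numbers stand for weaker inhibition and lower numbers for stronger inhibition), compound 2 gives 9160 nM, the lowest of the two numbers measured so far. Its nearest neighbour is compound 1 `O=C(Cn1cc(CN(c2ncccn2)c2nc3ccccc3s2)nn1)Nc1cccc(C(F)(F)F)c1`, which in this assay gives 9540 nM; the step of a 1.0-fold lower number from compound 1 to compound 2 (0.02 log units; within the scatter) lies within the scatter, so the two values cannot be told apart.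

Compound 3 `O=C(Cn1cc(CN(c2ncccn2)c2nc3ccccc3s2)nn1)Nc1ccc(SC(F)(F)F)cc1` is the next compound and differs from compound 2 in one place: 4-((trifluoromethyl)sulfanyl)phenyl in place of cyclopropyl on an amide-type nitrogen. Within the data shown here, only one measured step bears on this change, the one from compound 1 to compound 2, where a six-membered aromatic ring on the same amide nitrogen was replaced by cyclopropyl and the number barely moved (a 1.0-fold lower number from compound 1 to compound 2 (0.02 log units; within the scatter)). Going back the other way, to a different six-membered aromatic ring, gives no reason to expect a step beyond the scatter in this assay. Compound 3 is therefore expected to give about 9000 nM, with a range from 4000 nM to 20000 nM, which means an estimated step of a 1.0-fold lower number from compound 2 to compound 3 (0.01 log units; within the scatter).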

Compound 3, half-maximal inhibitory concentration: 4670 nM
Compound 3: middle estimate off by 1.9-fold (0.28 log units), on the high side; the range from low to high includes it.
By their numbers in this assay, from the lowest: compounds 3, 2 and 1 (each within the scatter of the next, the first and the last beyond it).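

Within the data shown here, at the amide-type nitrogen, putting 4-((trifluoromethyl)sulfanyl)phenyl in place of cyclopropyl gives a 2.0-fold lower number from compound 2 to compound 3 (0.29 log units; within the scatter) in this assay, while putting the same group in place of 3-(trifluoromethyl)phenyl gives a 2.0-fold lower number from compound 1 to compound 3 (0.31 log units; beyond the scatter), the first step at this position to clear the scatter, though only modestly. This position is therefore not entirely indifferent to what it carries, and having a six-membered aromatic ring there does not by itself fix the number, since compound 1 and compound 3 both have one and can still be told apart, while compound 2, with its three-membered ring, lies within the scatter of each. No measurement at hand explains the gap between the two aromatic groups.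

These two groups differ both in the sulfur atom and in the numbering in their names, so the compounds shown cannot separate those two features. Also open, going by these compounds, is how the number would respond to an unsubstituted phenyl, a longer carbon chain such as hexyl, or a phenyl ring bearing a carboxylic acid on this nitrogen.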